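The compounds below may be only part of what the source reports. "The series", "measured", "known", "first", "only" and "open" are said of these compounds alone.

Measured so far:

Compound 1, `ClCc1ccccc1Cn1cnc2c(Cl)nc(Cl)nc21`, gives 1510 nM in a functional assay on NCI-H23 cells (Homo sapiens) for cytotoxicity, read by sulforhodamine B assay, with a stated time of 48 h; a lower number here means a stronger inhibitor of growth, a higher number a weaker inhibitor of growth.
Compound 2, `ClCc1ccccc1Cn1cnc2c(Cl)ncnc21`, gives 2040 nM in this assay.
Compound 3, `ClCc1ccccc1Cn1cnc2ncnc(Cl)c21`, gives 5010 nM in this assay.

Compounds 1 and 2 share a core and differ in one place:

chloro in place of hydrogen on an aromatic carbon

That change made a step of a 1.4-fold lower number from compound 2 to compound 1 (0.13 log units; within the scatter).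

Compound 3 has the same atoms as compound 2, joined differently; the difference between the two cores is not broken down here. Compound 3 gives the highest of the three numbers.

Compound 4, `ClCc1ccccc1Cn1cnc2nc(Cl)nc(Cl)c21`, is not yet measured. It differs from compound 3 by the same change as the one from compound 2 to compound 1:

chloro in place of hydrogen on an aromatic carbon

For the measured compounds named here, the step from compound 3 to compound 4 is expected to be a 1.4-fold lower number from compound 3 to compound 4 (0.14 log units; within the scatter), resting on the only earlier example, a 1.4-fold lower number from compound 2 to compound 1 (0.13 log units; within the scatter), which lay within the scatter. Compound 4 is therefore estimated at 3600 nM, between 1600 nM and 8000 nM.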

Compound 4, concentration for 50% growth inhibition: 19100 nM
The estimate for compound 4 lay 5.3-fold (0.72 log units) below the measured number; the measured number lies above the stated range.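

Putting chloro in place of hydrogen gave a 3.8-fold higher number from compound 3 to compound 4 (0.58 log units; beyond the scatter) in this assay, so it did not repeat what the same change did on the other core: the same change on two cores in this assay, a 1.4-fold lower number (0.13 log units; within the scatter) from compound 2 to compound 1 and a 3.8-fold higher number (0.58 log units; beyond the scatter) from compound 3 to compound 4, 5.2-fold (0.71 log units) apart, beyond the scatter of two such steps

The size and even the direction of this step therefore changed with the core across these two pairs, and a step seen on one core was a poor guide to the other. Two pairs cannot show why the cores differ, nor how the change would behave on any further core.

The compounds shown carry only chloro or hydrogen at this place. On these data alone, how an amine or a methoxy group there would behave on either core remains open.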